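The compounds below may be only part of what the source reports. "The series", "measured", "known", "first", "only" and "open" are said of these compounds alone.

Measured so far in an assay on HEK293 cells for inhibition of Voltage-dependent T-type calcium channel subunit alpha-1G (Homo sapiens), read by fluorescence, tested at 10 uM; on this read-out higher numbers stand for more inhibition at the one concentration tested (going by the name of the read-out) and lower numbers for less inhibition:
compound 1 `CCCc1nc(-c2ccccc2)c(CNCCCN2CCN(c3ccccc3OC)CC2)o1` gives 41%;
compound 2 `CCCc1nc(-c2ccccc2)c(CNCCCN2CCN(c3ccccc3C(F)(F)F)CC2)o1` gives 45%;
compound 3 `CCCc1nc(-c2ccccc2)c(CNCCN2CCN(c3cccc(C)c3C)CC2)o1` gives 66.7%.

Compound 3 stands highest of the three, and its distance to both other compounds lies beyond the scatter, so its number in this assay is the highest of the set. Compound 4 `CCCc1nc(-c2ccccc2)c(CNCCN2CCN(c3ccccc3)CC2)o1` differs from compound 3 only in phenyl in place of 2,3-dimethylphenyl on an amine nitrogen in a ring. For the measured compounds named here, the one measured step, a number 4 percentage points higher from compound 1 to compound 2 (within the scatter), swaps one group for another on the aromatic ring attached to the same ring nitrogen and changed nothing beyond the scatter, but compounds 1 and 2 also differ from compound 3 elsewhere, so no measured step mirrors the loss of the two methyls. A modest fall is therefore expected, a number 16.7 percentage points lower from compound 3 to compound 4 (beyond the scatter). Compound 4 is estimated at 50%, within 30% to 70%.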

Compound 4, a percentage reported as inhibition, at one concentration (the size of the read-out at that concentration, not a potency): 54.3%
The estimate for compound 4 lay 4.3 percentage points below the measured number, within the range that was stated.
By their numbers in this assay, from the lowest: compounds 1, 2 and 4 (each within the scatter of the next, the first and the last beyond it); then compound 3.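

For the compounds shown here, removing the two methyls from the aromatic ring on the ring nitrogen is the first change here to move the number in this assay beyond the scatter (a number 12.4 percentage points lower from compound 3 to compound 4 (beyond the scatter)). The group at this position therefore matters, although compound 4, with plain phenyl, still gives 54.3%. No supporting data say why the 2,3-dimethylphenyl gives the higher number.

As far as these compounds go, it remains open whether one methyl alone would account for the step, and which one. Also open, from the compounds shown here alone, is how a chlorine or nitrile on this phenyl would read.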